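A few compounds are considered here, and "the series" means these few. Any claim that something is new, unique, unknown or untested is made for them only; others in the source may bear on it.

Working notes on the series in an assay on CHO cells for displacement of a labelled ligand from adenosine receptor A1 (Homo sapiens); on this read-out lower numbers stand for stronger inhibition and higher numbers for weaker inhibition.

Compound 1 `CCCn1c(=O)[nH]c2nc(-c3cnn(Cc4ccccc4)c3)[nH]c2c1=O` gives 1600 nM. Compound 2 `CCCn1c(=O)[nH]c2nc(-c3cnn(Cc4cccc(F)c4)c3)[nH]c2c1=O` gives 1800 nM, and the step of a 1.1-fold higher number from compound 1 to compound 2 (0.05 log units; within the scatter) shows that fluoro in place of hydrogen on an aromatic carbon left the number where it was. Compound 3 `CCCCn1c(=O)[nH]c2nc(-c3cnn(Cc4cccc(C(F)(F)F)c4)c3)[nH]c2c1=O` reaches only the limit > 6000 nM in this assay, a limit and not a number, as noted in the limit of > 6000 nM in this assay, at which 1 of the 3 values shown sits. Among the numbers shown, compound 2 stands highest of two, with compound 1 nearest and within the scatter of it.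

Compound 4 `CC(C)Cn1c(=O)[nH]c2nc(-c3cnn(Cc4cccc(F)c4)c3)[nH]c2c1=O` differs from compound 2 by methyl in place of hydrogen on a saturated chain carbon bound to two saturated chain carbons, that is, propyl to isobutyl on the chain of the shared core. For the measured compounds named here, no measured step isolates this change: compound 3 carries a longer chain but also a trifluoromethyl aryl group, so its limit cannot be read as a chain effect alone. Going by the values given here, the only measured step, from compound 1 to compound 2, was within the scatter and concerns the aryl part, not the chain. The expectation is therefore a step of a 1.3-fold higher number from compound 2 to compound 4 (0.11 log units; within the scatter) that is small, with a slight lean toward a higher number. Compound 4 is estimated at 2300 nM, in the range 900 nM to 6000 nM.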

Compound 4, inhibition constant: > 6000 nM
Compound 4: no number, only a limit (the forecaster's own chance of this, stated with the estimate: 20%); middle value at least 2.6-fold (0.41 log units) from the limit.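

The chain of the shared core matters in this assay: propyl to isobutyl gives an at least 3.3-fold higher number from compound 2 to compound 4 (0.52 log units; beyond the scatter), while the aryl change gave only a 1.1-fold higher number from compound 1 to compound 2 (0.05 log units; within the scatter). Going by these compounds, compound 4 has only a limit and no number, so the full size of this step stays unknown. The limit is also no longer confined to the compound with the trifluoromethyl aryl group: the limit of > 6000 nM in this assay, at which 2 of the 4 values shown sit.

On these data alone, it remains open whether the branch or the added carbon accounts for the step, as butyl appears only in compound 3, together with trifluoromethyl. Also open, as far as these compounds go, is how an ethyl chain, or a chain ending in an amine or a hydroxyl group, would read on this core.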